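This account rests on a few compounds, and the source may have more. Where it says the series, first, only, none or still open, it means among the compounds named here.

Measured in an ADME assay (Rattus norvegicus, strain Han-wistar) for pharmacokinetics, at a dose of 1.5 umol/kg by the intravenous route; on this read-out higher numbers stand for wider distribution into tissues and lower numbers for narrower distribution:

compound 1 `CNC(=O)CN1CCC(c2cc3c(-c4ccc(=O)n(C(C)C)c4)ccnc3[nH]2)CC1` gives 2.6 L/kg
compound 2 `CC(C)n1nc(-c2ccnc3[nH]c(C4CCN(CC(=O)N(C)C)CC4)cc23)ccc1=O` gives 2.9 L/kg
compound 3 `CC(C)n1cc(-c2ccnc3[nH]c(C4CCN(CC(=O)N(C)C)CC4)cc23)cnc1=O` gives 2.9 L/kg

These three values lie within the usual scatter of one another, so compound 1 stands together with compound 2 and compound 3 and not apart from them.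

Compound 4 `CC(C)n1cc(-c2ccnc3[nH]c(C4CCN(Cc5cccs5)CC4)cc23)ccc1=O` is still unmeasured. It departs from compound 1 by one change: thiophen-2-yl in place of methylcarbamoyl on a saturated chain carbon bound to an amine nitrogen in a ring. Cut one bond further out, this reads (methylcarbamoyl)methyl to (thiophen-2-yl)methyl.

Among the compounds with values here, the only measured step is no change at the digits printed from compound 2 to compound 3 (within the scatter) and it falls on an aromatic carbon, so it leaves the group changing here untouched. Within the data shown here, it sets no size for this change, and no measured step does.

The expectation therefore rests on the structural change alone, starting from compound 1 at 2.6 L/kg in this assay as the baseline. An upward move is expected, though with wide uncertainty. The expected step is a 2.3-fold higher number from compound 1 to compound 4 (0.36 log units; beyond the scatter) as an estimate. For compound 4 the estimated value is 6 L/kg with an expected range from 3 L/kg to 12 L/kg in this read-out.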

Compound 4, volume of distribution: 1.6 L/kg
The estimate for compound 4 lay 3.8-fold (0.57 log units) above the measured number; the whole stated range lies above it.
By their numbers in this assay, from the lowest: compounds 4, 1, 2 and 3 (each within the scatter of the next).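

Setting thiophen-2-yl in place of methylcarbamoyl on a saturated chain carbon bound to an amine nitrogen in a ring gives a 1.6-fold lower number from compound 1 to compound 4 (0.21 log units; within the scatter) in this assay. Within the data shown here, this is the first measured step at this position, and it shows that the amide group can give way to a sulfur-containing aromatic ring with no change in the read-out beyond the scatter. Nothing measured here explains this result.

The compounds shown leave open whether a carboxylic acid or an amine on the same chain carbon would take the number in this assay beyond the scatter. They also leave open whether thiophen-2-yl would give a similar result on the core of compound 2 or compound 3.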